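The source may report more compounds than this note shows. Statements on the series, on what has been measured and on what is new or still open speak of the compounds shown alone.

Compound 2 `O=C(CCCCCCc1ccccc1)c1ncc(-c2cccc(O)c2)o1` gives 50 nM in an assay (Rattus norvegicus) for inhibition of Fatty-acid amide hydrolase 1 (Homo sapiens) (on this read-out higher numbers stand for weaker inhibition and lower numbers for stronger inhibition), the lowest of the two numbers, though the scatter does not set it apart from compound 1 `COC(=O)c1ccccc1-c1cnc(C(=O)CCCCCCc2ccccc2)o1`, which gives 60 nM in this assay. Compound 3 `NC(=O)c1ccc(-c2cnc(C(=O)CCCCCCc3ccccc3)o2)cc1` carries 4-carbamoylphenyl in place of 3-hydroxyphenyl on an aromatic carbon. Among the measured compounds shown here, no step between measured compounds covers such a change, so in this assay a shift of moderate size is expected, with a slight lean toward a higher number. Compound 3 is therefore expected to give 80 nM, within 25 nM to 250 nM, which means an expected step of a 1.6-fold higher number from compound 2 to compound 3 (0.20 log units; within the scatter) of about the scatter.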

Compound 3, inhibition constant: 10 nM
The estimate for compound 3 lay 8.0-fold (0.90 log units) above the measured number; the measured number lies below the stated range.
By their numbers in this assay, from the lowest: compound 3; then compounds 2 and 1 (each within the scatter of the next).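

On the aromatic carbon next to the ring oxygen, the swap of 3-hydroxyphenyl for 4-carbamoylphenyl gives a 5.0-fold lower number from compound 2 to compound 3 (0.70 log units; beyond the scatter) in this assay and so separates compounds at this position, which compound 1 and compound 2 did not do within the scatter. The position therefore responds to the group it carries. Nothing given here accounts for the size of this step.

The change moves the substituent and replaces it at once, so the two effects stay unseparated. As far as these compounds go, whether 3-carbamoylphenyl, 4-hydroxyphenyl or a 4-carboxyphenyl group would match compound 3 remains open.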